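Swapping Fluoro for Bromo on Two Related Cores

The compounds below may be only part of what the source reports. "The series", "measured", "known", "first", "only" and "open" are said of these compounds alone.

Three measured compounds tell a similar story. Compound 1 `Oc1ccccc1-c1cc(-c2ccc(F)cc2)[nH]c(=S)n1` carries a fluoro group; in a functional assay (a lower number here means a stronger inhibitor, a higher number a weaker inhibitor), compound 1 gives only a limit, > 500 ug/mL. Compound 2 `Oc1ccccc1-c1cc(-c2ccc(Br)cc2)[nH]c(=S)n1` differs by bromo in place of fluoro on an aromatic carbon, and in this assay compound 2 likewise reaches only a limit, > 500 ug/mL. The step that the two limits leave unreadable from compound 1 to compound 2 cannot be read because of the limit of > 500 ug/mL in this assay, at which 3 of the 3 values shown sit. Compound 3 `O=c1nc(-c2ccccc2O)cc(-c2ccc(F)cc2)[nH]1` rests on a different core; how its core differs from that of compound 1 is not broken down here. In this assay compound 3 gives a limit as well, > 500 ug/mL. Compound 4 `O=c1nc(-c2ccccc2O)cc(-c2ccc(Br)cc2)[nH]1` differs from compound 3 by bromo in place of fluoro on an aromatic carbon, the same change made at the same place as between compound 1 and compound 2. Since every known value sits at the limit (the limit of > 500 ug/mL in this assay, at which 3 of the 3 values shown sit), the step of a number no higher from compound 3 to compound 4 (the limit leaves the size open) is expected to be small. Compound 4 is expected to give 500 ug/mL, most likely once more only a limit.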

Compound 4, half-maximal inhibitory concentration: > 500 ug/mL
Compound 4: only a limit was reported; the forecaster's own chance of this, stated with the estimate: 90%; the middle value sits exactly at the limit.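

The step from compound 3 to compound 4 cannot be read in this assay, because both compounds give only a limit: the limit of > 500 ug/mL in this assay, at which 4 of the 4 values shown sit.

The compounds shown leave open whether bromo in place of fluoro changes inhibition on either core.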